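Replacing the aromatic group of compound 2

A few compounds are considered here, and "the series" means these few. Any claim that something is new, unique, unknown or untested is made for them only; others in the source may bear on it.

Compound 1 `CC1(C)[C@H]2CC[C@]1(C)N(Cc1cn(-c3ccccc3C#N)nn1)C(=O)C2`: 100 nM
Compound 2 `COc1ccccc1-n1cc(CN2C(=O)C[C@@H]3CC[C@@]2(C)C3(C)C)nn1`: 350 nM

Both values come from a functional assay on A549 cells (Homo sapiens) for inhibition, read by MTT assay, with a stated time of 24 h (on this read-out higher numbers stand for weaker inhibition and lower numbers for stronger inhibition), where compound 2 has the higher number of the two. Compound 3 `CC1(C)[C@H]2CC[C@]1(C)N(Cc1cn(-c3ccc(Br)cc3)nn1)C(=O)C2` has 4-bromophenyl in place of 2-methoxyphenyl on an aromatic nitrogen. For the measured compounds named here, only one measured step bears on this change, a 3.5-fold higher number from compound 1 to compound 2 (0.54 log units; beyond the scatter), a modest one with methoxy in place of cyano on the same aromatic ring. Compound 3 carries neither of those groups, so its number is expected to fall between or near the two measured values. A small downward change is expected, a 1.8-fold lower number from compound 2 to compound 3 (0.24 log units; within the scatter). For compound 3 the estimated value is 200 nM, with an expected range from 70 nM to 600 nM.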

Compound 3, half-maximal inhibitory concentration: 80 nM
Compound 3: middle estimate off by 2.5-fold (0.40 log units), on the high side, within the range that was stated.
By their numbers in this assay, from the lowest: compounds 3 and 1 (each within the scatter of the next); then compound 2.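

In this assay, 4-bromophenyl in place of 2-methoxyphenyl on the aromatic nitrogen gives a 4.4-fold lower number from compound 2 to compound 3 (0.64 log units; beyond the scatter), so the higher number at this position is not shared by the other two aromatic groups. Set against the nitrile-bearing group, the same position gives a 1.3-fold lower number from compound 1 to compound 3 (0.10 log units; within the scatter), which leaves 2-cyanophenyl and 4-bromophenyl unseparated here. No measurement at hand accounts for this difference. The compounds shown leave open how this position responds to a phenyl group carrying an amine or a carboxylic acid, and whether chlorine or fluorine could stand in for the bromine.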